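A few compounds are considered here, and "the series" means these few. Any claim that something is new, unique, unknown or untested is made for them only; others in the source may bear on it.

Measured compounds in a functional assay on PC-3 cells (Homo sapiens) for antiproliferative activity, read by MTT assay, with a stated time of 48 h; on this read-out higher numbers stand for weaker inhibition and lower numbers for stronger inhibition:

Compound 1 `COc1cc(-c2nnc(SCC(=O)c3ccc(Br)cc3)n2N)cc(OC)c1OC` gives > 100000 nM, which is a limit of the assay rather than a number.
Compound 2 `COc1cc(-c2nnc(SCC(=O)c3ccc(C(F)(F)F)cc3)n2N)cc(OC)c1OC` gives > 100000 nM, again a limit of the assay and not a number.

Both values sit at the limit of > 100000 nM in this assay, at which 2 of the 2 values shown sit, so neither compound shows measurable inhibition on this read-out. Going by the values given here, the one measured step, trifluoromethyl in place of bromo on an aromatic carbon, is a step that the two limits leave unreadable from compound 1 to compound 2; with both ends at the same limit its size cannot be read, and it tells nothing about direction.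

Compound 3 `COc1cc(-c2nnc(SCC(=O)Nc3ccccc3C)n2N)cc(OC)c1OC` has not been measured. It differs from compound 2 by (2-methylphenyl)amino in place of 4-(trifluoromethyl)phenyl on a carbonyl carbon. Among the compounds with values here, no measured step bears on this change: the only step in hand alters a substituent on the aromatic ring that is here removed altogether, and it is itself unreadable. The shared core, the thioether chain and the carbonyl remain as in compound 2.

With the only measured point a limit, the expected step of a number no higher from compound 2 to compound 3 (the limit leaves the size open) for compound 3 in this assay is one of no readable size in either direction. The estimate for compound 3 in this assay is therefore 100000 nM, with a range from 25000 nM to 400000 nM, and a substantial chance that only a limit is again reported.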

Compound 3, half-maximal inhibitory concentration: > 100000 nM
Compound 3 was reported as a limit (the forecaster's own chance of this, stated with the estimate: 65%); the middle value lies on the limit itself.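

In this assay compound 3 gives > 100000 nM, a limit of the assay and not a number. No step among compound 1, compound 2 and compound 3 can be read, so none yields a size or direction: the limit of > 100000 nM in this assay, at which 3 of the 3 values shown sit.

The compounds shown leave open whether any change to this series gives a measurable value in this assay.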